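Changing the Fluorinated Ring on the Amide Carbonyl

A few compounds are considered here, and "the series" means these few. Any claim that something is new, unique, unknown or untested is made for them only; others in the source may bear on it.

Two compounds share one core and differ only in the aryl ring attached to the amide carbonyl. Compound 1 `O=C(Nc1cccc(-c2oc3cc(-c4ccc(F)cc4)ccc3c(=O)c2O)c1)c1ccc(F)cc1` is the simpler of the pair, and in a functional assay on MDA-MB-231 cells (Homo sapiens) for antiproliferative activity, read by CCK-8 assay, with a stated time of 72 h (a higher number here means a weaker inhibitor, a lower number a stronger inhibitor), compound 1 gives 16000 nM. Compound 2 `Cc1cc(C(=O)Nc2cccc(-c3oc4cc(-c5ccc(F)cc5)ccc4c(=O)c3O)c2)ccc1F` carries a methyl in place of hydrogen on an aromatic carbon of that ring, and in this assay compound 2 gives 7440 nM. Among the measured compounds shown here, the step of a 2.2-fold lower number from compound 1 to compound 2 (0.33 log units; beyond the scatter) is the only measured step, and it leaves compound 2 with the lower of the two numbers.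

Compound 3 `O=C(Nc1cccc(-c2oc3cc(-c4ccc(F)cc4)ccc3c(=O)c2O)c1)c1cc(F)cc(F)c1` has not yet been measured. Its difference from compound 2 is 3,5-difluorophenyl in place of 4-fluoro-3-methylphenyl on a carbonyl carbon. For the measured compounds named here, the one known step, a 2.2-fold lower number from compound 1 to compound 2 (0.33 log units; beyond the scatter), concerns a methyl rather than a rearranged fluorine pattern, so it bears on this change only loosely: compound 3 gives up the methyl that separated compound 2 from compound 1, and nothing measured shows what the 3,5-difluorophenyl itself does. The expectation is therefore a small move toward the number of compound 1, with no confident direction beyond the scatter. The estimate for compound 3 in this assay is 11000 nM, with a range from 4000 nM to 30000 nM, which is expected to mean a step of a 1.5-fold higher number from compound 2 to compound 3 (0.17 log units; within the scatter).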

Compound 3, half-maximal inhibitory concentration: 2440 nM
Beside the measured number, compound 3's estimate is 4.5-fold (0.65 log units) above it; measured number outside the range, below it.
By their numbers in this assay, from the lowest: compound 3; then compound 2; then compound 1.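

Replacing 4-fluoro-3-methylphenyl with 3,5-difluorophenyl on the carbonyl carbon gives, in this assay, a 3.0-fold lower number from compound 2 to compound 3 (0.48 log units; beyond the scatter), so the lowest number of the three belongs to a ring with no methyl at all. Measured against the plain 4-fluorophenyl ring, the same 3,5-difluorophenyl ring gives a 6.6-fold lower number from compound 1 to compound 3 (0.82 log units; beyond the scatter), which shows that this position can shift the number further than the methyl alone had shown, and that a methyl is not the only change that lowers it. No measurement available here explains why these rings differ in this way.

Compound 3 differs from compound 1 in both the number of fluorines and where they sit, so these compounds cannot show whether the lower number depends on the second fluorine, on the new fluorine pattern, or on both. Also open, as far as these compounds go, is how the number would respond to other groups on this ring, such as a methoxy group, a nitrile or a trifluoromethyl group, or to an amine in place of a fluorine.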